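Ethynyl in place of benzofuranyl: expected gain in potency

The source may hold more compounds than are shown below. What is called first, only, known or untested is meant among the compounds shown, and "the series" means these compounds.

Measured in a functional assay on CEM-DNR-bulk cells (Homo sapiens), read by MTT assay, with a stated time of 72 h; a higher number here means a weaker inhibitor, a lower number a stronger inhibitor:
- compound 1 `C#Cc1cn([C@@H]2O[C@H](CO)[C@@H](O)[C@H]2O)c2ncnc(OC)c12`: 3490 nM
- compound 2 `COc1nc(N)nc2c1c(-c1cc3ccccc3o1)cn2[C@@H]1O[C@H](CO)[C@@H](O)[C@H]1O`: 16700 nM

Of these two compounds, compound 2 has the higher number and is therefore the weaker inhibitor, and the gap to compound 1 lies beyond the scatter. Among the measured compounds shown here, the two differ in more than one place, so no clean single-change step is available yet.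

The next comparison starts from compound 2 and moves to compound 3 `C#Cc1cn([C@@H]2O[C@H](CO)[C@@H](O)[C@H]2O)c2nc(N)nc(OC)c12`, which carries ethynyl in place of 1-benzofuran-2-yl on an aromatic carbon. The rest of the structure stays the same.

For the measured compounds named here, the only guide is compound 1, which also bears an ethynyl group and gives 3490 nM. This points towards a lower number in this assay, though the evidence is thin. A moderate move towards stronger inhibition is expected, an estimated 3.3-fold lower number from compound 2 to compound 3 (0.52 log units; beyond the scatter). For compound 3 the expected value is 5000 nM, with an estimated range of 1500 nM to 15000 nM.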

Compound 3, half-maximal inhibitory concentration: > 20000 nM
Compound 3: no number, only a limit (the forecaster's own chance of this, stated with the estimate: 10%); at least 4.0-fold (0.60 log units) between middle value and limit.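

Compound 3 gives > 20000 nM in this assay, a limit and not a number: the limit of > 20000 nM in this assay, at which 1 of the 3 values shown sits.

The replacement of 1-benzofuran-2-yl by ethynyl gives an at least 1.1-fold higher number from compound 2 to compound 3 (0.07 log units; that floor lies within the scatter), so the floor of this step shows no gain in potency at this aromatic carbon, and ethynyl alone does not carry the lower number seen for compound 1. Among the compounds shown here, the first single-change step with ethynyl held fixed, amino in place of hydrogen, gives an at least 5.7-fold higher number from compound 1 to compound 3 (0.75 log units; beyond the scatter), which places a loss beyond the scatter on the amino change; both compounds bearing amino, compound 2 and compound 3, give higher numbers than compound 1, and none of the three goes against this.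

Going by these compounds, how far compound 3 lies past its limit stays open, so the true size and even the direction of the ethynyl step cannot be fixed, and whether amino costs as much alongside 1-benzofuran-2-yl cannot be read from these compounds. Also open, on these data alone, is whether a methylamino or a hydroxyl group in place of the amino, or a longer alkynyl chain in place of ethynyl, would return the number towards that of compound 1.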